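Cyano in place of ethyl on the pendant phenyl ring

This account rests on a few compounds, and the source may have more. Where it says the series, first, only, none or still open, it means among the compounds named here.

Measured compounds in an assay for displacement of a labelled ligand from melanin-concentrating hormone receptor 1 (Homo sapiens), read by fluorescence; on this read-out higher numbers stand for weaker inhibition and lower numbers for stronger inhibition:
compound 1 `CC(=O)Nc1cccc(C2CCN(CCCn3c(-c4ccc(Br)cc4)nc4ccccc43)CC2)c1` gives 5 nM
compound 2 `CCc1ccc(-c2nc3ccccc3n2CCCN2CCC(c3cccc(NC(C)=O)c3)CC2)cc1` gives 32 nM

Going by the values given here, compound 2 stands at the higher of the two numbers in this assay, the only step to it being a 6.4-fold higher number from compound 1 to compound 2 (0.81 log units; beyond the scatter), which lies beyond the scatter. Compound 3 `CC(=O)Nc1cccc(C2CCN(CCCn3c(-c4ccc(C#N)cc4)nc4ccccc43)CC2)c1` differs from compound 2 by cyano in place of ethyl on an aromatic carbon. Among the compounds with values here, no measured step bears directly on this change; the only step known concerns compound 1 and compound 2, where a 6.4-fold higher number from compound 1 to compound 2 (0.81 log units; beyond the scatter) shows that a change at this position can move the number by a modest amount. With cyano differing from both bromo and ethyl at this place, the step from compound 2 to compound 3 is expected to be a 2.1-fold lower number from compound 2 to compound 3 (0.33 log units; beyond the scatter), a partial return toward the number of compound 1 rather than a move beyond it. Compound 3 is therefore estimated at 15 nM, with a range from 4 nM to 60 nM.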

Compound 3, half-maximal inhibitory concentration: 16 nM
For compound 3 the middle estimate is 1.1-fold (0.03 log units) below the measured one; low and high end bracket the measured number.
By their numbers in this assay, from the lowest: compound 1; then compounds 3 and 2 (each within the scatter of the next).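

In this assay, replacing ethyl with cyano on the aromatic carbon para to a large group gives a 2.0-fold lower number from compound 2 to compound 3 (0.30 log units; within the scatter), so within the scatter these two groups cannot be told apart at this position. Replacing bromo with cyano gives a 3.2-fold higher number from compound 1 to compound 3 (0.51 log units; beyond the scatter), which lies beyond the scatter, so among the three groups compared here, compound 1 alone stands apart, at the lowest number, and neither of the other compounds goes against this. Nothing at hand accounts for why bromo separates from the other two groups.

The compounds shown leave open how a chloro group, a methoxy group, an amine or a carboxylic acid would read at this place. They also leave open whether the gap between bromo and cyano would persist with a change elsewhere on the shared core.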